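The compounds below may be only part of what the source reports. "The series", "measured", "known", "first", "only" and "open" are said of these compounds alone.

Measured in a functional assay (plasma) for inhibition, with Homo sapiens as the target; a lower number here means a stronger inhibitor, a higher number a weaker inhibitor:
- Compound 1 `CCCCCCOC[C@@H]1C2CCC(O2)[C@H]1C/C=C\CCCC(=O)O`: 25000 nM; 18000 nM; 500 nM (3 entries)
- Compound 2 `CCC/C=C/COCC1C2CCC(O2)C1C/C=C\CCCC(=O)O`: 300 nM
- Compound 3 `CCCCCCOC(C)C1C2CCC(O2)C1C/C=C\CCCC(=O)O`: 14000 nM

Compound 2 gives 300 nM, the lower of the two compounds with a single number. Compound 3 gives 14000 nM, a gap well beyond the usual scatter. Compound 1 has no single number, and its entries lie far apart: the several entries of compound 1 in this assay, 25000 nM; 18000 nM; 500 nM (3 entries).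

The next compound is compound 4 `C=CCOCC1C2CCC(O2)C1C/C=C\CCCC(=O)O`. Its difference from compound 2 is vinyl in place of pent-1-en-1-yl on a saturated chain carbon bound to an oxygen on a saturated carbon. Put another way, hex-2-en-1-yl gives way to allyl, and none of the measured compounds carries a chain as short as allyl. Among the compounds with values here, no measured pair isolates a change of this kind, so the expectation is tentative. It starts from compound 2 at 300 nM, and a clear move in this assay towards a higher number, meaning a weaker inhibitor, is expected, beyond the scatter. The expected change is a 10-fold higher number from compound 2 to compound 4 (1.00 log units; beyond the scatter). For compound 4 the estimated value is 3000 nM, with an expected range of 600 nM to 15000 nM.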

Compound 4, half-maximal inhibitory concentration: 6000 nM
For compound 4 the middle estimate is 2.0-fold (0.30 log units) below the measured one; low and high end bracket the measured number.
By their numbers in this assay, from the lowest: compound 2; then compound 4; then compound 3.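

In this assay, cutting the chain on the ether oxygen from hex-2-en-1-yl to allyl gives a 20-fold higher number from compound 2 to compound 4 (1.30 log units; beyond the scatter). Within the data shown here, this is the first change at this position that can be read on its own, and it shows that the length of this chain matters in this assay, as both chains keep one double bond outside any ring and neither adds a hydrogen-bond donor, a hydrogen-bond acceptor or a charge. The compounds shown offer no measurement that explains the size of this step.

From the compounds shown here alone, it remains open whether the number changes gradually with chain length, as an intermediate but-2-en-1-yl chain would show, or whether a longer chain such as oct-2-en-1-yl would give a still lower number. The contribution of the double bond itself also remains unsettled, and a saturated propyl chain in place of allyl would address it.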